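This account rests on a few compounds, and the source may have more. Where it says the series, first, only, none or still open, it means among the compounds named here.

Working notes on the series in a functional assay on HCT-116 cells (Homo sapiens) for cytotoxicity; a higher number here means a weaker inhibitor, a lower number a stronger inhibitor. Compound 1 `CCCCCCCCCCCCC/C=C/C1=N[C@@H]1C(=O)OC` gives 18200 nM, compound 2 `COC(=O)[C@H]1N=C1/C=C/CCCCCCCCCC=C(Br)Br` gives 19600 nM, and compound 3 `COC(=O)[C@@H]1N=C1/C=C\CCCCCCCCC/C=C(/Cl)Br` gives 13600 nM. All three numbers lie within the scatter of one another, so compound 3 is not separated from either of the others.

Compound 4 `COC(=O)[C@@H]1N=C1/C=C/CCCCCCCCC/C=C(/Cl)Br` differs from compound 3 in configuration only: the two compounds have the same atoms and bonds and differ only in configuration as drawn: 1 of 3 stereo elements differ; a double bond is drawn Z in compound 3 and E in compound 4.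

For the measured compounds named here, no measured step isolates such a change. Going by the values given here, the only step measured in one place is a 1.1-fold higher number from compound 1 to compound 2 (0.03 log units; within the scatter), which exchanges butyl for 2,2-dibromoethenyl and stays within the scatter. Among the compounds with values here, the data therefore hold no direct precedent for the switch from Z to E. Compound 1 and compound 2 are both drawn E at this double bond, and their numbers do not separate from that of the Z compound 3, though they differ from it elsewhere too.

No change beyond the scatter is expected in this assay, in either direction. The expected step is a 1.2-fold higher number from compound 3 to compound 4 (0.07 log units; within the scatter). The estimated value for compound 4 is 16000 nM, with an expected range of 9000 nM to 28000 nM.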

Compound 4, half-maximal inhibitory concentration: 15200 nM
Beside the measured number, compound 4's estimate is 1.1-fold (0.02 log units) above it, and the stated range covers the measured number.
By their numbers in this assay, from the lowest: compounds 3, 4, 1 and 2 (each within the scatter of the next).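

In this assay, for the compounds shown here, the switch of this double bond from Z to E gives a 1.1-fold higher number from compound 3 to compound 4 (0.05 log units; within the scatter), the first measured step that isolates a change of configuration. Where compounds 1, 2 and 3 could only hint at this, since the E compounds differ from compound 3 elsewhere too, this pair shows directly that the double bond's geometry does not separate the two numbers, at least with this chain end. The reading belongs to this double bond alone, because nothing else in the structure changes: the fact that compounds 3 and 4 differ only in the configuration as drawn

Going by these compounds, whether the same holds with the other chain ends remains open, as the pair covers one chain end only. Also open, on these data alone, is how the series would read in this assay with a carboxylic acid or an amide in place of the methyl ester.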